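The source may report more compounds than this note shows. Statements on the series, on what has been measured and on what is new or still open speak of the compounds shown alone.

Measured in an ADME assay on microsomes from liver (Homo sapiens) for metabolic stability, read by HPLC, using NADPH, with a stated time of 60 min, tested at 1 uM, in the presence of a further agent that is not named here; on this read-out higher numbers stand for a longer-lived compound and lower numbers for a shorter-lived compound:
- compound 1 `O=C(NNS(=O)(=O)c1ccccc1F)c1cc(F)cc(-n2cccn2)c1`: 1.6 h
- compound 2 `O=C(NNS(=O)(=O)c1ccccc1F)c1cc(F)cc(-c2ccccn2)c1`: 0.933 h
- compound 3 `Cc1cc(-c2ncccn2)cc(C(=O)NNS(=O)(=O)c2ccccc2)c1F`: 2.72 h

Compound 2 matches compound 1 within the usual scatter, while compound 3 reads higher than compound 2, beyond the scatter.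

The next compound to be tested is compound 4 `C=CCOc1cc(F)cc(C(=O)NNS(=O)(=O)c2ccccc2F)c1`. It differs from compound 2 as follows: allyloxy in place of pyridin-2-yl on an aromatic carbon. In plain words, allyloxy stands in place of pyridin-2-yl.

Among the measured compounds shown here, only one measured step bears on this carbon: a 1.7-fold lower number from compound 1 to compound 2 (0.23 log units; within the scatter). That step exchanges one ring for another, whereas allyloxy has no ring, so it offers only weak guidance. The expected step in this assay is a 1.2-fold lower number from compound 2 to compound 4 (0.07 log units; within the scatter), with no clear shift beyond the scatter. For compound 4 the estimated half-life is 0.8 h, with an expected range of 0.35 h to 1.8 h.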

Compound 4, half-life: 0.217 h
Estimate against measurement, compound 4: 3.7-fold (0.57 log units) above, and the stated range ends above it.
By their numbers in this assay, from the lowest: compound 4; then compounds 2, 1 and 3 (each within the scatter of the next, the first and the last beyond it).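

In this assay, the group on this carbon now makes a clear difference: with allyloxy, which has no ring, the data show a 4.3-fold lower number from compound 2 to compound 4 (0.63 log units; beyond the scatter) and also a 7.4-fold lower number from compound 1 to compound 4 (0.87 log units; beyond the scatter) as steps. Among the compounds shown here, the one earlier change here, a ring for a ring, gave only a 1.7-fold lower number from compound 1 to compound 2 (0.23 log units; within the scatter) and so did not show this. No measurement at hand explains the drop.

Open, going by these compounds, is whether the missing ring, the oxygen or the double bond matters most. A saturated propoxy chain or a plain phenyl ring on this carbon would help separate these.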